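A few compounds are considered here, and "the series" means these few. Any claim that something is new, unique, unknown or untested is made for them only; others in the source may bear on it.

Measured in a functional assay on HL-60 cells (Homo sapiens) for inhibition, read by CCK-8 assay, with a stated time of 48 h; a lower number here means a stronger inhibitor, a higher number a weaker inhibitor:
- Compound 1 `COc1ccc(NC(=O)NCCNS(=O)(=O)c2sccc2-c2ccc(C)cc2Oc2ccc(O)c(O)c2)cc1`: 6100 nM
- Compound 2 `O=S(=O)(NCCNC(=S)Nc1cc(C(F)(F)F)cc(C(F)(F)F)c1)c1ccc(-c2ccccc2O[C@H]2CC[C@@H](O)CC2)s1`: 2600 nM
- Compound 3 `COc1ccc(Oc2ccccc2-c2ccsc2S(=O)(=O)N2CCN(C(=O)Nc3cccc([N+](=O)[O-])c3)CC2)cc1OC`: > 50000 nM (a limit of the assay, not a number)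

Going by the values given here, only two compounds have true numbers. Compound 2 gives 2600 nM, while compound 1 has the higher number at 6100 nM, a gap beyond the usual scatter.

Compound 4 `Cc1ccc(-c2ccsc2S(=O)(=O)NCCNC(=S)Nc2ccc([N+](=O)[O-])cc2)c(Oc2ccc(O)c(O)c2)c1` is not yet measured. It replaces the (4-methoxyphenyl)carbamoyl of compound 1, on an amine nitrogen, with a group that has no common name: a group of 12 heavy atoms (7 carbon, 2 nitrogen, 2 oxygen, 1 sulfur; one six-membered aromatic ring of carbon only) in place of a group of 11 heavy atoms (8 carbon, 1 nitrogen, 2 oxygen; one six-membered aromatic ring of carbon only), on an amine nitrogen. Among the compounds with values here, no measured pair isolates this change. Compound 2 at 2600 nM also carries a thiocarbonyl, so a small move toward a lower number is expected, probably not beyond the scatter. The expected change is a 1.5-fold lower number from compound 1 to compound 4 (0.18 log units; within the scatter). For compound 4 the estimated value is 4000 nM, with an expected range of 1200 nM to 14000 nM.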

Compound 4, half-maximal inhibitory concentration: 2900 nM
Estimate against measurement, compound 4: 1.4-fold (0.14 log units) above, within the range that was stated.
By their numbers in this assay, from the lowest: compounds 2 and 4 (each within the scatter of the next); then compound 1. At a limit, above all of these: compound 3.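

In this assay, going by these compounds alone, the group of 12 heavy atoms, which carries a sulfur, replaces the (4-methoxyphenyl)carbamoyl on the amine nitrogen and gives a 2.1-fold lower number from compound 1 to compound 4 (0.32 log units; beyond the scatter) in the first comparison of compounds that differ in one place. So a change at this nitrogen can move the number beyond the scatter, though the step is modest. Nothing measured here explains the step.

Going by these compounds, the two groups differ in more than the sulfur, so the share of each difference stays open. Also open, on these data alone, is how a group bearing an amine or a carboxylic acid would read in this place.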